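The compounds below may be only part of what the source reports. "The series", "measured", "known", "first", "only" and "open" are said of these compounds alone.

Values measured so far in a physicochemical assay for lipophilicity, at pH 7.8; on this read-out higher numbers stand for higher lipophilicity and lower numbers for lower lipophilicity:

- Compound 1 `O=C(O)c1cccc(C2=C(c3cc(Cl)ccc3OCc3ccccc3)CCC2)c1`: 3
- Compound 2 `Cc1ccc(-c2cc(Cl)ccc2OCC(C)C)n1-c1cccc(C(=O)O)c1`: 3.1
- Compound 3 `O=C(O)c1nc(Cc2cc(Cl)ccc2OCc2ccccc2)cs1`: 1.1

Compound 3, at 1.1, has the lowest of these three numbers. Compound 1 gives 3 and compound 2 gives 3.1, and each of these lies above compound 3 by more than repeated measurements usually scatter.

The next compound to be measured is compound 4 `O=C(O)c1cnc(Cc2cc(Cl)ccc2OCc2ccccc2)s1`. It contains the same atoms as compound 3, joined differently: 5-carboxy-1,3-thiazol-2-yl in place of 2-carboxy-1,3-thiazol-4-yl on a saturated chain carbon bound to an aromatic carbon. In words, 5-carboxy-1,3-thiazol-2-yl stands in place of 2-carboxy-1,3-thiazol-4-yl on a saturated chain carbon bound to an aromatic carbon.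

Among the measured compounds shown here, none of the measured compounds differ from each other in only one place, so the data offer no direct precedent for a change of this kind. The best anchor is therefore compound 3 itself, with its 1.1, and a rearrangement that leaves the atoms unchanged suggests only a modest shift. The expected change is a slight rise, estimated as a number 0.20 log units higher from compound 3 to compound 4 (within the scatter), which would not stand clearly beyond the scatter. In this assay, the estimated value for compound 4 is 1.3, with an expected range from 0.7 to 1.9.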

Compound 4, distribution coefficient: 0.9
Compound 4: middle estimate off by 0.40 log units, on the high side, within the range that was stated.
By their numbers in this assay, from the lowest: compounds 4 and 3 (each within the scatter of the next); then compounds 1 and 2 (each within the scatter of the next).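

In this assay, among the compounds shown here, the thiazole acid can be rearranged on a saturated chain carbon bound to an aromatic carbon, with 5-carboxy-1,3-thiazol-2-yl in place of 2-carboxy-1,3-thiazol-4-yl, and this gives a number 0.20 log units lower from compound 3 to compound 4 (within the scatter) as the first step in this set between compounds that differ in only one place. The two groups contain the same atoms and match in every count, and this step shows that, at this position and in this one pair, joining those atoms differently does not separate the compounds on this read-out beyond ordinary repeat variation. Nothing measured here offers an explanation for this result, so the pair records an outcome and not a reason.

As far as these compounds go, what stays open is whether the same holds when the carboxylic acid on this ring is replaced by a primary amide or a tetrazole, or when a longer chain stands in place of the saturated chain carbon. Compound 1 and compound 2 differ from this pair in more than one place, so their values cannot show how either change would behave.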